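This account rests on a few compounds, and the source may have more. Where it says the series, first, only, none or still open, it means among the compounds named here.

Notes on the series. Compound 1 `C/C=C/C=C/C(=O)N(Cc1ccc(OC)c(O)c1)c1cc(OC)c(OC)c(OC)c1` gives the lowest of the three numbers in a functional assay on HCT-116 cells (Homo sapiens) for inhibition, read by MTT assay, with a stated time of 48 h (a higher number here means a weaker inhibitor, a lower number a stronger inhibitor), at 180 nM. Compound 2 `COc1ccc(N(Cc2cc(OC)c(OC)c(OC)c2)C(=O)CCl)cc1O` gives 22500 nM in this assay, and compound 3 `C/C=C/C(=O)N(Cc1ccc(OC)c(OC)c1)c1cc(OC)c(OC)c(OC)c1` gives 32800 nM; both gaps to compound 1 lie beyond the scatter. Compound 4 `COc1ccc(CN(C(=O)C(C)Br)c2cc(OC)c(OC)c(OC)c2)cc1O` is not yet measured. It differs from compound 1 in one place: 1-bromoethyl in place of penta-1,3-dien-1-yl on a carbonyl carbon. For the measured compounds named here, no measured pair isolates this change, and compound 2 and compound 3, the only other numbers, both sit far weaker than compound 1. With the penta-1,3-dien-1-yl gone, the expected outcome is a clear loss, a 56-fold higher number from compound 1 to compound 4 (1.74 log units; beyond the scatter), beyond the scatter. Compound 4 is estimated at 10000 nM, with a range from 2000 nM to 40000 nM.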

Compound 4, half-maximal inhibitory concentration: 140 nM
Compound 4: the middle estimate sits 71-fold (1.85 log units) above what was measured, and the stated range ends above it.
By their numbers in this assay, from the lowest: compounds 4 and 1 (each within the scatter of the next); then compounds 2 and 3 (each within the scatter of the next).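

On the carbonyl carbon whose other neighbour is the amide-type nitrogen, 1-bromoethyl in place of penta-1,3-dien-1-yl gives a 1.3-fold lower number from compound 1 to compound 4 (0.11 log units; within the scatter) in this assay on this pair. The 2 double bonds outside aromatic rings in penta-1,3-dien-1-yl are thus not needed at this position for a number of this order. No measurement on hand explains why the two groups read alike. As far as these compounds go, whether the bromine matters remains open, as a plain ethyl group would test. So does the reach of this position toward a longer chain, an amine or a carboxylic acid.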